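The source may hold more compounds than are shown below. What is called first, only, known or untested is meant among the compounds shown, and "the series" means these compounds.

In a functional assay (aorta) with Rattus norvegicus as the target (a lower number here means a stronger inhibitor, a higher number a weaker inhibitor), compound 1 `CC1(C)Oc2ccc(C#N)cc2[C@H](Nc2ccccc2)[C@H]1O` gives 1200 nM. That is the lower of the two numbers in this assay; the other belongs to compound 3 `CCOC(=O)C(=O)N(c1ccc(F)cc1)[C@H]1c2cc(C#N)ccc2OC(C)(C)[C@@H]1O`, which gives 43000 nM, a gap well beyond the usual scatter. Compound 2 `CCOC(=O)CN(c1ccc(F)cc1)[C@H]1c2cc(C#N)ccc2OC(C)(C)[C@@H]1O` reaches only a limit in this assay, > 30000 nM. The step that the limit leaves unreadable from compound 2 to compound 3 cannot be sized, because the limit of > 30000 nM in this assay, at which 1 of the 3 values shown sits, hides where compound 2 truly sits. Compound 4 `CCOC(=O)NN(c1ccccc1)[C@H]1c2cc(C#N)ccc2OC(C)(C)[C@@H]1O` differs from compound 1 by (ethoxycarbonyl)amino in place of hydrogen on a nitrogen on an aromatic ring. Among the compounds with values here, no measured step covers exactly this change. What the numbers do show is that the two compounds whose nitrogen on an aromatic ring carries an ester-bearing group, compound 2 and compound 3, sit at or near the top of this assay's range, while compound 1, with hydrogen on that nitrogen, gives the lower number; compound 2 and compound 3 also carry a fluorine that compound 1 lacks, so the comparison is not clean. On that basis compound 4 is expected to be weaker in this assay than compound 1, by the step of an 8.3-fold higher number from compound 1 to compound 4 (0.92 log units; beyond the scatter). The estimate for compound 4 is 10000 nM, with a likely range from 2000 nM to 50000 nM.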

Compound 4, half-maximal inhibitory concentration: 2200 nM
Beside the measured number, compound 4's estimate is 4.5-fold (0.66 log units) above it, and the stated range covers the measured number.
By their numbers in this assay, from the lowest: compounds 1 and 4 (each within the scatter of the next); then compound 3.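

In this assay the change of hydrogen to (ethoxycarbonyl)amino on this nitrogen appears as a 1.8-fold higher number from compound 1 to compound 4 (0.26 log units; within the scatter), so compound 1 and compound 4 cannot be told apart, even though the entering group brings 6 heavy atoms. Compound 2 and compound 3 differ from compound 1 in more than one place, so they could not show this, and compound 4 now shows that an ester-bearing group on a group attached to this nitrogen can sit on the core of compound 1 without a change beyond the scatter. Nothing measured here gives a reason for this result.

Still open, going by these compounds, is whether a plain amino group, or a carboxylic acid in place of the ethyl ester, would give a similar number at this place. Within the data shown here, also open is what a fluorine on the aromatic ring does when it is the only change.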